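The compounds below may be only part of what the source reports. "The series", "measured", "known", "first", "only" and "open" are said of these compounds alone.

In an ADME assay on BJ cells (Homo sapiens) for cytotoxicity, read by CellTiter-Glo and resazurin assay, with a stated time of 72 h (on this read-out higher numbers stand for an effect only at larger amounts of compound and lower numbers for an effect already at smaller amounts), three compounds have been measured so far. Compound 1 `CC(C)N(Cc1cccc(OCCCCCC(=O)O)c1)C(=O)c1ccccc1` carries only hydrogen on an aromatic carbon of the shared core; in this assay compound 1 gives a limit, > 26000 nM. Compound 2 `CC(C)N(Cc1cccc(OCCCCCC(=O)O)c1)C(=O)c1ccc(-c2cccc(-c3ccccc3)c2)cc1` carries a 3-phenylphenyl on that carbon, and compound 2 also gives a limit of > 26000 nM. Compound 3 `COc1cccc(-c2ccc(C(=O)N(Cc3cccc(OCCCCCC(=O)O)c3)C(C)C)cc2)c1` carries a 3-methoxyphenyl there, and compound 3 gives a limit of > 20900 nM. Going by the values given here, all three readings are limits rather than numbers, so the steps a step that the two limits leave unreadable from compound 1 to compound 2, a step that the two limits leave unreadable from compound 1 to compound 3 and a step that the two limits leave unreadable from compound 2 to compound 3 cannot be sized; the only information is the limit of > 26000 nM in this assay, at which 2 of the 3 values shown sit, and (the limit of > 20900 nM in this assay, at which 1 of the 3 values shown sits). Compound 3 therefore stands where the other two stand, at a limit.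

Compound 4 `CC(C)N(Cc1cccc(OCCCCCC(=O)O)c1)C(=O)c1ccc(-c2ccc3[nH]ccc3c2)cc1` differs from compound 3 by 1H-indol-5-yl in place of 3-methoxyphenyl on an aromatic carbon. Among the compounds with values here, none of the measured steps can be read, so they give no direction for this change; the expectation rests only on every measured compound sitting at a limit. The step from compound 3 to compound 4 is expected to be a step that the limit leaves unreadable from compound 3 to compound 4, that is, none beyond the scatter. Compound 4 is accordingly expected to give 30000 nM, within a range from 15000 nM to 60000 nM, and most likely again only a limit.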

Compound 4, half-maximal effective concentration: > 26000 nM
Compound 4: a limit, no number; the forecaster's own chance of this, stated with the estimate: 85%; the middle value does not contradict the limit.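

Compound 4 gives only a limit, as do compound 1, compound 2 and compound 3, so none of the steps from those three compounds to compound 4 can be read. The compounds shown leave open at what concentration any of the four would reach a half-maximal effect in this assay, and whether changing the group on that aromatic carbon alters this at all.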